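This account rests on a few compounds, and the source may have more. Where it says the series, first, only, none or still open, it means among the compounds named here.

Of the compounds shown here, two from this series have been measured in an assay on isolated protein for displacement of a labelled ligand from metabotropic glutamate receptor 5 (Homo sapiens), with a stated time of 60 min, tested at 1 uM; on this read-out lower numbers stand for less inhibition and higher numbers for more inhibition at the one concentration tested (going by the name of the read-out). Compound 1 `COc1ccc2ncc(S(=O)(=O)c3cc(F)cc(F)c3)c(N3CCC(C)CC3)c2c1` gives 30%. Compound 2 `CC1CCN(c2c(S(=O)(=O)c3cccc(F)c3)cnc3ccc(Cl)cc23)CC1` gives 58%, the highest of the two numbers, and its nearest neighbour is compound 1, which stands beyond the scatter below it. Compound 3 `CC1CCN(c2c(S(=O)(=O)c3cc(F)cc(F)c3)cnc3ccc(Cl)cc23)CC1` has not yet been tested in this assay. It differs from compound 2 in one place: fluoro in place of hydrogen on an aromatic carbon. Compound 3 is expected to show a step of a number 8 percentage points lower from compound 2 to compound 3 (within the scatter), small and downward if anything, not beyond the scatter. Compound 3 is estimated to give 50%, within a range from 30% to 70%.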

Compound 3, a percentage reported as inhibition, at one concentration (the size of the read-out at that concentration, not a potency): 93%
For compound 3 the middle estimate is 43 percentage points below the measured one, and the stated range ends below it.
By their numbers in this assay, from the lowest: compound 1; then compound 2; then compound 3.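

In this assay, the change from 3-fluorophenyl to 3,5-difluorophenyl gives a number 35 percentage points higher from compound 2 to compound 3 (beyond the scatter), so this aromatic carbon responds strongly to a single added fluoro when chloro is on the core. With 3,5-difluorophenyl present in both compounds, chloro in place of methoxy gives a number 63 percentage points higher from compound 1 to compound 3 (beyond the scatter), so the second fluoro does not set the read-out independently of the rest of the structure. Nothing available explains either step.

Going by these compounds, it remains open whether a nitrile or an amine at this aromatic carbon would give a similar read-out. Whether the fluoro step also holds with methoxy on the core is open too.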